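From tert-butyl to carboxy on the aromatic ring

The compounds below may be only part of what the source reports. "The series", "measured", "known", "first", "only" and "open" are said of these compounds alone.

In a functional assay on A549 cells (Homo sapiens) for cytotoxicity, read by MTT assay, with a stated time of 48 h (a higher number here means a weaker inhibitor, a lower number a stronger inhibitor), compound 1 `CC1(C)CCC[C@]2(C)[C@@H](CC[C@@](C)(O)/C=C/c3ccccc3)[C@](C)(O)CC[C@@H]12`, which carries a plain phenyl, gives 3150 nM. Compound 2 `COc1cccc(OC)c1/C=C/[C@](C)(O)CC[C@@H]1[C@@]2(C)CCCC(C)(C)[C@@H]2CC[C@@]1(C)O`, with 2,6-dimethoxyphenyl in its place, gives 42000 nM, and compound 3 `CC(C)(C)c1ccc(/C=C/[C@](C)(O)CC[C@@H]2[C@@]3(C)CCCC(C)(C)[C@@H]3CC[C@@]2(C)O)cc1`, with 4-(tert-butyl)phenyl, gives 45000 nM. Compound 3 therefore sits level with compound 2, at the weak end of this small set, and the two are separated only by a 1.1-fold higher number from compound 2 to compound 3 (0.03 log units; within the scatter).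

Compound 4 `CC1(C)CCC[C@]2(C)[C@@H](CC[C@@](C)(O)/C=C/c3ccc(C(=O)O)cc3)[C@](C)(O)CC[C@@H]12` has carboxy in place of tert-butyl on an aromatic carbon, para to a large group: carboxy in place of tert-butyl on an aromatic carbon. For the measured compounds named here, no measured step makes this exact swap. The closest evidence is that substituting the phenyl gave large steps both times, a 13-fold higher number from compound 1 to compound 2 (1.12 log units; beyond the scatter) and a 14-fold higher number from compound 1 to compound 3 (1.15 log units; beyond the scatter), while two quite different substituted rings ended up together. On only these two examples, compound 4 is expected to stay near compound 3 rather than return to compound 1. The expected change is a 1.5-fold lower number from compound 3 to compound 4 (0.18 log units; within the scatter), which is no real shift. For compound 4 the estimated value is 30000 nM, with an expected range from 7000 nM to 90000 nM.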

Compound 4, half-maximal inhibitory concentration: 44300 nM
For compound 4 the middle estimate is 1.5-fold (0.17 log units) below the measured one; the measured number falls inside the stated range.
By their numbers in this assay, from the lowest: compound 1; then compounds 2, 4 and 3 (each within the scatter of the next).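

In this assay, carboxy in place of tert-butyl on the aromatic carbon makes no real difference (a 1.0-fold lower number from compound 3 to compound 4 (0.01 log units; within the scatter)), although one group of only carbon is exchanged for one carrying oxygen and a hydrogen-bond donor. Compound 4 also sits level with the 2,6-dimethoxyphenyl analogue (a 1.1-fold higher number from compound 2 to compound 4 (0.02 log units; within the scatter)) and, like the other two substituted compounds, stays far from the plain phenyl (a 14-fold higher number from compound 1 to compound 4 (1.15 log units; beyond the scatter)), so three quite different substituted rings now read alike. Nothing available here accounts for this shared level.

The compounds shown leave open whether a single fluorine, a methyl or a methoxy at this same place would also move the number away from that of compound 1. They also leave open whether an amine or a methyl ester in place of carboxy would stay at the same level.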